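Swapping an aromatic group for oxan-4-yl

The compounds below may be only part of what the source reports. "The series", "measured", "known", "first", "only" and "open" are said of these compounds alone.

- Compound 1 `CO[C@H]1CC[C@H](NC(=O)c2n[nH]cc2NC(=O)c2c(C)nc3ccccn23)CC1` gives 34000 nM here
- Compound 2 `CO[C@H]1CC[C@H](NC(=O)c2n[nH]cc2NC(=O)c2cnc3ccccn23)CC1` gives 5900 nM here
- Compound 3 `COc1cccc(OC)c1C(=O)Nc1c[nH]nc1C(=O)NC1CCN(C(=O)OC(C)(C)C)CC1` gives > 50000 nM here

All three results come from an ADME assay on MRC5 cells (Homo sapiens) for inhibition, with a stated time of 72 h; a higher number here means that more compound is needed for the effect, a lower number that less compound is needed. Compound 2 has the lower of the two true numbers. The result for compound 3 is a limit of the assay and not a number.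

The next structure is compound 4 `CO[C@H]1CC[C@H](NC(=O)c2n[nH]cc2NC(=O)C2CCOCC2)CC1`, which differs from compound 2 in one group on a carbonyl carbon: a group of 6 heavy atoms (5 carbon, 1 oxygen; one six-membered non-aromatic ring with 1 hetero atom) in place of a group of 9 heavy atoms (7 carbon, 2 nitrogen; one five-membered aromatic ring with 2 hetero atoms, one six-membered aromatic ring with 1 hetero atom), on a carbonyl carbon.

Within the data shown here, only one measured step bears on this, and only loosely: a 5.8-fold lower number from compound 1 to compound 2 (0.76 log units; beyond the scatter). That step was just hydrogen in place of methyl on an aromatic carbon, a much smaller structural change than this one. Even so, it moved the number beyond the scatter, so a real shift is expected here too. Among the measured compounds shown here, with compound 2 holding the lowest number so far, that shift is expected to go upward. The expected change is a 3.4-fold higher number from compound 2 to compound 4 (0.53 log units; beyond the scatter). For compound 4 the estimated value is 20000 nM, with an expected range from 6000 nM to 50000 nM.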

Compound 4, half-maximal effective concentration: > 50000 nM
Compound 4: a limit, no number; the forecaster's own chance of this, stated with the estimate: 30%; at least 2.5-fold (0.39 log units) between middle value and limit.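

In this assay, among these compounds, the earlier compounds showed only what a small edit on the aromatic group does, whereas exchanging that whole group on the carbonyl carbon for oxan-4-yl gives an at least 8.4-fold higher number from compound 2 to compound 4 (0.92 log units; beyond the scatter). Compound 4 gives > 50000 nM, which is a limit of the assay and not a number. The step therefore has a known minimum but no known top, because the read-out stops at that limit: the limit of > 50000 nM in this assay, at which 2 of the 4 values shown sit.

The compounds shown leave open whether the loss of aromatic rings or some other feature of this exchange sets the result, and a plain phenyl ring or a piperidine ring on the same carbonyl carbon would help separate these. From the compounds shown here alone, how far compound 4 truly lies from compound 2 also remains unknown.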